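From 2-chlorobenzyl to 3-chlorobenzyl: compound 1 and compound 4

The source may hold more compounds than are shown below. What is called first, only, known or untested is meant among the compounds shown, and "the series" means these compounds.

- compound 1 `O=C(Nc1cccc(Cl)c1)Nc1cc2ncncc2cc1OCc1ccccc1Cl`: 2600 nM
- compound 2 `O=C(Nc1ccc(Cl)c(Cl)c1)Nc1cc2ncncc2cc1OCc1cccc(F)c1`: 2100 nM
- compound 3 `O=C(Nc1cccc(F)c1)Nc1cc2ncncc2cc1OCc1ccccc1Cl`: 4000 nM

In a functional assay on GBM1 cells (Homo sapiens) for antiproliferative activity, read by WST assay, with a stated time of 72 h (a lower number here means a stronger inhibitor, a higher number a weaker inhibitor), compound 1 gives 2600 nM. The values of compound 2 and compound 3 both lie within the usual scatter of that number, so compound 1 holds no distinct rank among the three.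

The next compound, compound 4 `O=C(Nc1cccc(Cl)c1)Nc1cc2ncncc2cc1OCc1cccc(Cl)c1`, has the same atoms as compound 1, joined differently: 3-chlorophenyl in place of 2-chlorophenyl on a saturated chain carbon bound to an oxygen on an aromatic ring. In short, 3-chlorophenyl takes the place of 2-chlorophenyl on a saturated chain carbon bound to an oxygen on an aromatic ring.

For the measured compounds named here, no measured step makes this exact change. The closest evidence is the swap of fluoro for chloro on an aromatic carbon, a 1.5-fold higher number from compound 1 to compound 3 (0.19 log units; within the scatter), which is made elsewhere in the molecule. Going by the values given here, compound 2 differs from compound 1 in more than one place, so it offers no single step.

Among the compounds with values here, with only that small step as a guide, no shift beyond the scatter is expected in this assay, and the expected step is a 1.0-fold lower number from compound 1 to compound 4 (0.02 log units; within the scatter). The estimated value for compound 4 is 2500 nM, with an expected range from 1000 nM to 6000 nM.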

Compound 4, half-maximal inhibitory concentration: 3300 nM
Estimate against measurement, compound 4: 1.3-fold (0.12 log units) below, within the range that was stated.
By their numbers in this assay, from the lowest: compounds 2, 1, 4 and 3 (each within the scatter of the next).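

In this assay, for the compounds shown here, the exchange of 2-chlorobenzyl for 3-chlorobenzyl gives a 1.3-fold higher number from compound 1 to compound 4 (0.10 log units; within the scatter) and is the first direct test of the group on the oxygen, as the earlier single step changed a halogen elsewhere in the molecule. Moving the chlorine from one of these two ring places to the other therefore produces no change that can be told apart from the ordinary spread of repeated measurements. Nothing measured here bears on why the number stays within that spread.

Still open, on these data alone, is whether plain benzyl, with no chlorine at all, or methoxy in place of the chlorine would shift the number beyond that spread. As far as these compounds go, a longer chain, such as 2-phenylethyl in place of the benzyl group, remains an equally open question.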